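The source may hold more compounds than are shown below. What is called first, only, known or untested is meant among the compounds shown, and "the series" means these compounds.

Of the compounds shown here, two have been measured so far in a physicochemical assay for lipophilicity; on this read-out higher numbers stand for higher lipophilicity and lower numbers for lower lipophilicity. Compound 1 (`CCCC(=O)Oc1c(OC)c(OC)c(OC(=O)CCC)c2ccccc12`) gives 4.64, and compound 2 (`COc1c(OC)c(OC(C)=O)c2c(Cl)cccc2c1OC(C)=O`) gives 3.16. Compound 2 therefore stands as the lower of the two numbers, and the gap between them lies beyond the usual scatter of such measurements.

Compound 3 (`COc1c(OC)c(OC(C)=O)c2c(NC(C)=O)cccc2c1OC(C)=O`) has yet to be measured in this assay. It differs from compound 2 in one place, with acetamido in place of chloro on an aromatic carbon. Among the measured compounds shown here, no step between measured compounds covers this kind of change, so the expectation rests on the structural change alone. A downward step beyond the scatter is expected, with the estimate being a number 1.16 log units lower from compound 2 to compound 3 (beyond the scatter). The expected value for compound 3 is 2, with an estimated range from 1.4 to 2.6.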

Compound 3, partition coefficient: 2
Compound 3: middle estimate and measured number agree at the digits printed; the range from low to high includes it.
By their numbers in this assay, from the lowest: compound 3; then compound 2; then compound 1.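

In this assay, the position on the aromatic carbon ortho to a fused ring and meta to a fused ring proves responsive: acetamido in place of chloro gives a number 1.16 log units lower from compound 2 to compound 3 (beyond the scatter) as a large step. Among the compounds shown here, this is the first reading of a change at one place, as compounds 1 and 2 differ in more than one place and their gap could not be assigned to this position. The change replaces one heavy atom with four and adds a hydrogen-bond donor and acceptor, but nothing available explains the size of the step.

As far as these compounds go, it remains open whether an amine or a carboxylic acid at this position would give a similar step. From the compounds shown here alone, it is also open whether acetamido in place of chloro would give a step of this size on the core of compound 1.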